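The source may report more compounds than this note shows. Statements on the series, on what has been measured and on what is new or still open speak of the compounds shown alone.

Measured compounds:
- compound 1 `Cn1c2c(c3ccccc3c1=O)CCOc1ccccc1-2`; in a functional assay on HL-60 cells (Homo sapiens) for cytotoxicity, read by sulforhodamine B assay (on this read-out lower numbers stand for stronger inhibition and higher numbers for weaker inhibition), compound 1 gives 37600 nM
- compound 2 `Cc1ccc2c(=O)n(C)c3c(c2c1)CCOc1ccccc1-3`; in this assay compound 2 gives 33600 nM
- compound 3 `COc1ccc(Cn2c3c(c4ccccc4c2=O)CCOc2ccccc2-3)cc1`; in this assay compound 3 gives 4490 nM

Compound 3 holds the lowest number of the three, beyond the scatter from both others; the step of an 8.4-fold lower number from compound 1 to compound 3 (0.92 log units; beyond the scatter) is the larger of the two measured steps, while compound 2 and compound 1 sit within the scatter of each other. The unmeasured compound 4 `COc1ccc(Cn2c3c(c4cc(C)ccc4c2=O)CCOc2ccccc2-3)cc1` carries the change (methyl in place of hydrogen on an aromatic carbon). The same change has been seen once, as a 1.1-fold lower number from compound 1 to compound 2 (0.05 log units; within the scatter), a step within the scatter. Among the compounds with values here, no other measured step bears on it. In this assay the expected step is therefore none beyond the scatter, a 1.1-fold lower number from compound 3 to compound 4 (0.03 log units; within the scatter). Compound 4 is accordingly estimated at 4200 nM, with a range from 2000 nM to 9000 nM.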

Compound 4, half-maximal inhibitory concentration: 9260 nM
For compound 4 the middle estimate is 2.2-fold (0.34 log units) below the measured one, outside the stated range (above it).
By their numbers in this assay, from the lowest: compound 3; then compound 4; then compounds 2 and 1 (each within the scatter of the next).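

In this assay the methyl is no longer silent on the core of compound 3, giving a 2.1-fold higher number from compound 3 to compound 4 (0.31 log units; beyond the scatter) where the core of compound 1 showed a step within the scatter. Even so, the two methyl steps do not separate: the same change on two cores in this assay, a 1.1-fold lower number (0.05 log units; within the scatter) from compound 1 to compound 2 and a 2.1-fold higher number (0.31 log units; beyond the scatter) from compound 3 to compound 4, 2.3-fold (0.36 log units) apart, within the scatter of two such steps.

The 4-methoxyphenyl gain persists with the methyl present, as a 3.6-fold lower number from compound 2 to compound 4 (0.56 log units; beyond the scatter), and does not separate from the gain without it: the same change on two cores in this assay, an 8.4-fold lower number (0.92 log units; beyond the scatter) from compound 1 to compound 3 and a 3.6-fold lower number (0.56 log units; beyond the scatter) from compound 2 to compound 4, 2.3-fold (0.36 log units) apart, within the scatter of two such steps.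

Going by these compounds, what an amine or a carboxylic acid in place of the methyl on this aromatic carbon would give stays open, as does a longer chain in place of the 4-methoxyphenyl.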